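Aryl swap on the sulfonyl sulfur of compound 2

A few compounds are considered here, and "the series" means these few. Any claim that something is new, unique, unknown or untested is made for them only; others in the source may bear on it.

Of the compounds shown here, two have numbers so far in a functional assay on HepG2 cells (Homo sapiens) for antiproliferative activity, read by MTT assay, with a stated time of 48 h; on this read-out higher numbers stand for an effect only at larger amounts of compound and lower numbers for an effect already at smaller amounts. Compound 1 (`CC1=NN(C(=O)c2ccc(F)cc2)C(c2ccccc2O)C1`) gives 39200 nM and compound 2 (`CC1=NN(S(=O)(=O)c2ccccc2C)C(c2cc(Br)ccc2O)C1`) gives 39300 nM in this assay, so the two stand level within the scatter and neither can be ranked over the other.

Compound 3 (`CC1=NN(S(=O)(=O)c2ccc(Cl)cc2Cl)C(c2cc(Br)ccc2O)C1`) carries 2,4-dichlorophenyl in place of 2-methylphenyl on a sulfonyl sulfur. For the measured compounds named here, no measured pair isolates a change at this place. Going by the values given here, the only guide is that compound 1 at 39200 nM and compound 2 at 39300 nM lie level although their structures differ in more than one place. No step beyond the scatter is therefore expected, with any drift expected toward a lower number. The estimated change is a 1.4-fold lower number from compound 2 to compound 3 (0.15 log units; within the scatter) in this assay. For compound 3 the estimated value is 28000 nM, with an expected range of 11000 nM to 65000 nM in this assay.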

Compound 3, half-maximal effective concentration: 45200 nM
Beside the measured number, compound 3's estimate is 1.6-fold (0.21 log units) below it; the range from low to high includes it.
By their numbers in this assay, from the lowest: compounds 1, 2 and 3 (each within the scatter of the next).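

In this assay, for the compounds shown here, 2,4-dichlorophenyl in place of 2-methylphenyl on a sulfonyl sulfur gives a 1.2-fold higher number from compound 2 to compound 3 (0.06 log units; within the scatter), the first step that isolates this position. At this place, on a sulfonyl sulfur whose other neighbours are the sulfonamide nitrogen in a ring, exchanging one carbon-only aromatic ring for another that carries two chlorine atoms therefore leaves the read-out within the scatter. No measurement on hand bears on why the number holds at this place.

As far as these compounds go, whether an aminophenyl, a carboxylic acid on the aryl ring or a plain alkyl chain on the sulfonyl sulfur would give a step beyond the scatter remains open. From the compounds shown here alone, the effect of a carbonyl in place of the sulfonyl also remains open, since compound 1 and compound 2 differ in more than one place.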